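Nitrophenyl position shift on two related cores

The compounds below may be only part of what the source reports. "The series", "measured", "known", "first", "only" and "open" are said of these compounds alone.

Compound 1 `CCOC(=O)C1=C(C)NC(=O)NC1c1cn(C(=O)CNc2ccccc2[N+](=O)[O-])c2ccccc12` is the starting point of this note; in a physicochemical assay for lipophilicity (on this read-out lower numbers stand for lower lipophilicity and higher numbers for higher lipophilicity), compound 1 gives 1.48. Compound 2 `CCOC(=O)C1=C(C)NC(=S)NC1c1cn(C(=O)CNc2ccccc2[N+](=O)[O-])c2ccccc12` gives 2.88 in this assay, and compound 3 `CCOC(=O)C1=C(C)NC(=S)NC1c1cn(C(=O)CNc2cccc([N+](=O)[O-])c2)c2ccccc12` gives 2.88. The difference between the core of compound 1 and the core of compound 2 is not broken down here; their two values only show compound 1 lying lower than compound 2 by a gap beyond the scatter. From compound 2 to compound 3 the change is 3-nitrophenyl in place of 2-nitrophenyl on an amine nitrogen, and the step that it made is no change at the digits printed from compound 2 to compound 3 (within the scatter). Compound 4 `CCOC(=O)C1=C(C)NC(=O)NC1c1cn(C(=O)CNc2cccc([N+](=O)[O-])c2)c2ccccc12` is not yet measured. It differs from compound 1 by 3-nitrophenyl in place of 2-nitrophenyl on an amine nitrogen, the same change at the same place, an amine nitrogen whose other neighbour is a saturated chain carbon. The expectation for compound 4 rests on this single matched pair, because compound 2 to compound 3 showed no change at the digits printed from compound 2 to compound 3 (within the scatter) on the core of compound 2. The expected step is therefore no change at the digits printed from compound 1 to compound 4 (within the scatter). Compound 4 is estimated at 1.48, with a range expected from 1.05 to 1.95.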

Compound 4, partition coefficient: 1.48
Estimate against measurement, compound 4: no gap at the digits printed; the measured number falls inside the stated range.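

In this assay, 3-nitrophenyl in place of 2-nitrophenyl on an amine nitrogen gave no change at the digits printed from compound 1 to compound 4 (within the scatter), and the same change gave no change at the digits printed from compound 2 to compound 3 (within the scatter), so the change carried across the two cores shown without a step beyond the scatter. Among the compounds shown here, these cores themselves read apart in this assay, with compound 1 at 1.48 and compound 2 at 2.88, yet this is only one matched pair on each core and does not show that the result holds on any further core or on any other read-out. No measurement in hand bears on why the two nitrophenyl groups give matching numbers on either core.

Still open, from the compounds shown here alone, is whether the same flat result would appear with an amine or a carboxylic acid in place of the nitro group on the phenyl ring. Also open, going by these compounds, is whether it would survive a longer chain in place of the saturated chain carbon on the amine nitrogen.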